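A few compounds are considered here, and "the series" means these few. Any claim that something is new, unique, unknown or untested is made for them only; others in the source may bear on it.

Measured so far in a toxicity assay on HepG2 cells (Homo sapiens) for inhibition, read by CellTiter-Glo, with a stated time of 48 h; on this read-out lower numbers stand for stronger inhibition and higher numbers for weaker inhibition:

- compound 1 `COc1ccc2nc(C)cc(OCC(=O)Nc3ccc(Cl)cc3Cl)c2c1` gives > 100000 nM, which is a limit of the assay and not a number.
- compound 2 `COc1ccc2nc(C)cc(OCC(=O)Nc3cc(OC)c(OC)c(OC)c3)c2c1` gives > 100000 nM, again a limit of the assay rather than a number.

Compound 1 therefore stands at the edge of what this assay can report, and it does not stand alone there: the limit of > 100000 nM in this assay, at which 2 of the 2 values shown sit, shows both measured values resting on that same limit. Neither compound gave a number that could be placed on a scale, so no order between them can be read.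

Compound 3 `COc1ccc2nc(C)cc(OCC(=O)Nc3noc(C)c3C)c2c1` is the compound still to be measured. It differs from compound 1 in a single place:

4,5-dimethyl-1,2-oxazol-3-yl in place of 2,4-dichlorophenyl on an amide-type nitrogen

Within the data shown here, no two measured compounds in this set differ in just one place, so there is no measured step to lean on. The expected step from compound 1 to compound 3 in this assay is a step that the limit leaves unreadable from compound 1 to compound 3, with nothing expected beyond the usual scatter. Compound 3 is expected to give 150000 nM, within a range from 50000 nM to 500000 nM, and most likely the assay will again report only a limit.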

Compound 3, half-maximal inhibitory concentration: > 100000 nM
Compound 3: only a limit was reported; the forecaster's own chance of this, stated with the estimate: 80%; the middle value is on the limit's open side.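

No step can be read between compound 1 and compound 3, since in this assay both give only a limit of the assay and not a number: the limit of > 100000 nM in this assay, at which 3 of the 3 values shown sit.

The compounds shown leave open how far each one lies beyond that limit, and whether any group on the amide-type nitrogen would give a readable number in this assay.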